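Moving the pyridine nitrogen in a low-stability series

This account rests on a few compounds, and the source may have more. Where it says the series, first, only, none or still open, it means among the compounds named here.

Compound 1, `CCn1c(=O)/c(=C2\Sc3cc(F)ccc3N2C)s/c1=C\c1ccccn1`: 5%
Compound 2, `CCn1c(=O)/c(=C2\Sc3cc(Cl)ccc3N2C)s/c1=C\c1ccccn1`: 13%
Compound 3, `CCn1c(=O)/c(=C2\Sc3c(Cl)cccc3N2C)s/c1=C\c1ccccn1`: 17%

In an ADME assay on microsomes from liver (Mus musculus) for metabolic stability, with a stated time of 30 min (a lower number here means that less of the compound is left, a higher number that more of the compound is left), compound 1 gives 5%, the lowest of the three numbers shown. Its nearest neighbour is compound 2, reached by a number 8 percentage points higher from compound 1 to compound 2 (within the scatter). Among the compounds with values here, the furthest is compound 3, whose value of 17% stands beyond the scatter from compound 1; no single-point step is defined between these two, so only the two values themselves can be compared.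

Compound 4, `CCn1c(=O)/c(=C2\Sc3cc(F)ccc3N2C)s/c1=C\c1ccncc1`, differs from compound 1 by pyridin-4-yl in place of pyridin-2-yl on a double-bonded chain carbon bound to an aromatic carbon. Within the data shown here, the only measured step in the set, the halogen swap from compound 1 to compound 2, changes a substituent on the shared core and leaves the pyridyl ring untouched; it was within the scatter. Among the measured compounds shown here, no measured step touches the pyridyl ring at all, so nothing in the data points to a change in this assay beyond the scatter in either direction. The step from compound 1 to compound 4 is therefore expected to be a number 2 percentage points higher from compound 1 to compound 4 (within the scatter), essentially flat. Compound 4 is estimated at 7%, with a likely range from 2% to 20%, keeping it in the same low band as compound 1.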

Compound 4, percent of the compound remaining: 13%
For compound 4 the middle estimate is 6 percentage points below the measured one, within the range that was stated.
By their numbers in this assay, from the lowest: compounds 1, 2, 4 and 3 (each within the scatter of the next, the first and the last beyond it).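

Within the data shown here, at this place, on a double-bonded chain carbon bound to an aromatic carbon, the swap of pyridin-2-yl for pyridin-4-yl gives in this assay a number 8 percentage points higher from compound 1 to compound 4 (within the scatter) and is the first measured change to the pyridyl ring in this set. The group that leaves and the group that enters have the same heavy atoms and the same counts of donors and acceptors, so this step compares only two ways of joining the same atoms, and that difference stays within the scatter, as does the halogen change on the shared core, a number 8 percentage points higher from compound 1 to compound 2 (within the scatter). Nothing measured here bears on what lies behind the size of this step.

From the compounds shown here alone, it remains open whether pyridin-3-yl or a plain phenyl ring at this place would give a step beyond the scatter in this assay. The compounds shown also leave open how pyridin-4-yl behaves when chloro replaces fluoro on the shared core, and whether an amine or a carboxylic acid on the pyridyl ring would move the number at all.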